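The source may report more compounds than this note shows. Statements on the series, on what has been measured and on what is new or still open speak of the compounds shown alone.

Of the compounds shown here, three built on one shared core have been tested in an assay on CHO-K1 cells for displacement of a labelled ligand from prostaglandin E2 receptor EP1 subtype (Homo sapiens); a lower number here means a stronger inhibitor, a higher number a weaker inhibitor. Compound 1 `Cc1cc(C(=O)O)nn1Cc1cc(Br)ccc1OCc1ccc(F)cc1F` gives 0.525 nM. Compound 2 `Cc1cc(C(=O)O)nn1Cc1cc(Br)ccc1OCc1c(F)cccc1F` gives 14.8 nM, and compound 3 `Cc1cc(C(=O)O)nn1Cc1cc(Br)ccc1OCc1cccc(Br)c1` gives 17.8 nM. Among the three numbers, compound 1 stands lowest: the rise is a 28-fold higher number from compound 1 to compound 2 (1.45 log units; beyond the scatter) and a 34-fold higher number from compound 1 to compound 3 (1.53 log units; beyond the scatter), while the comparison of the other two is a 1.2-fold higher number from compound 2 to compound 3 (0.08 log units; within the scatter). All three differ from one another only in the aromatic group carried on a saturated chain carbon bound to an oxygen on an aromatic ring.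

Compound 4 `Cc1cc(C(=O)O)nn1Cc1cc(F)ccc1OCc1ccc(F)cc1F` has not yet been measured in this assay . It differs from compound 1 at a different place: fluoro in place of bromo on an aromatic carbon, on an aromatic carbon of a six-membered aromatic ring of carbon only, meta to a large group and para to a large group. Within the data shown here, none of the measured steps touches this position; each of them concerns the other aromatic group, so none bears directly on this change. Without a guiding step, the change is expected to be modest, and the step from compound 1 to compound 4 is expected to be a 2.9-fold higher number from compound 1 to compound 4 (0.46 log units; beyond the scatter). Compound 4 is therefore expected to give 1.5 nM, within a range from 0.4 nM to 6 nM.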

Compound 4, half-maximal inhibitory concentration: < 2000 nM
Compound 4 ended at the assay's limit; the forecaster's own chance of this, stated with the estimate: 2%; the middle value lies beyond the limit too.
By their numbers in this assay, from the lowest: compound 1; then compounds 2 and 3 (each within the scatter of the next).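

In this assay compound 4 gives a limit rather than a number, so no step from compound 1 to compound 4 can be read: the limit of < 2000 nM in this assay, at which 1 of the 4 values shown sits.

The compounds shown leave open how large the change from bromo to fluoro on this aromatic carbon really is, and whether it would differ with the aromatic groups of compound 2 or compound 3.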